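This account rests on a few compounds, and the source may have more. Where it says the series, first, only, none or still open, it means among the compounds named here.

Measured so far:
compound 1 `CCOC(=O)C(=O)Nc1cccccc1=O`: 79%
compound 2 `CCOC(=O)C(=O)Nc1ccccc(OC)c1=O`: 59%

In a functional assay on the whole organism (strain Sprague-Dawley CD) for inhibition, with Rattus norvegicus as the target, read by paw edema, at a dose of 30 mg/kg by the oral route (on this read-out lower numbers stand for a weaker effect and higher numbers for a stronger effect at the one dose given), compound 1 gives 79%, the highest of the two numbers. Compound 2 gives 59%, and the step of a number 20 percentage points lower from compound 1 to compound 2 (beyond the scatter) is beyond the scatter. Compound 3 `CC(C)(C)OC(=O)C(=O)Nc1cccccc1=O` is not yet measured in this assay. It differs from compound 1 by tert-butyl in place of ethyl on an oxygen next to a carbonyl group. Going by the values given here, the only measured step, a number 20 percentage points lower from compound 1 to compound 2 (beyond the scatter), concerns a methoxy in place of hydrogen on an aromatic carbon and leaves the ester untouched, so no measured step bears on the change from ethyl to tert-butyl on the oxygen next to the carbonyl group. With no guide from the series on this change, the expected step of a number 9 percentage points lower from compound 1 to compound 3 (within the scatter) is small, within or at the edge of the scatter, in no firm direction. Compound 3 is therefore estimated at 70%, with a range from 50% to 88%.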

Compound 3, a percentage reported as inhibition, in the whole organism at one dose (the size of the read-out at that dose, not a potency): 47%
The estimate for compound 3 lay 23 percentage points above the measured number; the measured number lies below the stated range.
By their numbers in this assay, from the lowest: compound 3; then compound 2; then compound 1.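

The oxygen next to a carbonyl group is not a silent place in the series: in this assay, tert-butyl in place of ethyl gives a number 32 percentage points lower from compound 1 to compound 3 (beyond the scatter). The read-out therefore responds to a change at this oxygen as well as on the aromatic carbon, where methoxy in place of hydrogen gave a number 20 percentage points lower from compound 1 to compound 2 (beyond the scatter). No measurement available here accounts for the drop seen with tert-butyl.

As far as these compounds go, with only ethyl and tert-butyl at this oxygen, it remains open whether the number falls steadily across such groups or only with tert-butyl, and isopropyl, a longer chain such as butyl, or the free carboxylic acid would help separate these cases. Also open, from the compounds shown here alone, is how the change at this oxygen and the methoxy change on the aromatic carbon behave when present together.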